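Moving the methyl group from compound 2 to compound 3

The source may hold more compounds than are shown below. What is called first, only, known or untested is meant among the compounds shown, and "the series" means these compounds.

- compound 1 `NC(=O)c1cc(Br)ccc1NC(=O)/C=C/c1cccc(Br)c1`: > 10000 nM (a limit)
- compound 2 `Cc1ccccc1/C=C/C(=O)Nc1ccc(Br)cc1C(N)=O`: > 10000 nM (a limit)

In a functional assay on K562 cells (Homo sapiens) for inhibition, read by trypan blue exclusion, with a stated time of 48 h (a lower number here means a stronger inhibitor, a higher number a weaker inhibitor), compound 2 gives > 10000 nM, which is a limit and not a number. Compound 3 `Cc1ccc(/C=C/C(=O)Nc2ccc(Br)cc2C(N)=O)cc1` differs from it in one place: 4-methylphenyl in place of 2-methylphenyl on a double-bonded chain carbon bound to a double-bonded chain carbon, with 4-methylphenyl in place of 2-methylphenyl. Going by the values given here, the only measured step bearing on this is a step that the two limits leave unreadable from compound 1 to compound 2, and the series so far offers only (the limit of > 10000 nM in this assay, at which 2 of the 2 values shown sit). No readable size is available, so no step beyond the scatter is expected in this assay. The expected step is a step that the limit leaves unreadable from compound 2 to compound 3. Compound 3 is expected at 15000 nM, with an estimated range of 5000 nM to 40000 nM.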

Compound 3, half-maximal inhibitory concentration: > 10000 nM
Compound 3 gave a limit, no number; the forecaster's own chance of this, stated with the estimate: 80%; the middle value does not contradict the limit.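

In this assay no step can be read among compound 1, compound 2 and compound 3, as all three values are limits and not numbers. Left open is whether 3-bromophenyl, 2-methylphenyl and 4-methylphenyl differ at all, with the series resting on one value: the limit of > 10000 nM in this assay, at which 3 of the 3 values shown sit.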